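Swapping a chloro for isopropoxy: expected cytotoxicity of compound 3

This account rests on a few compounds, and the source may have more. Where it says the series, first, only, none or still open, it means among the compounds named here.

Compound 1 `COc1ccc(C2=C(c3cc(OC)c(OC)c(OC)c3)C(=O)C(OC(C)=O)C2)cc1Cl` was tested in an ADME assay on HEK293 cells (Homo sapiens) for cytotoxicity, read by MTT assay, with a stated time of 72 h (on this read-out higher numbers stand for weaker inhibition and lower numbers for stronger inhibition), where compound 1 gives 60 ug/mL. For the measured compounds named here, that is the only actual number in this set. Compound 2 `COc1ccc(C2=C(c3cc(OC)c(OC)c(OC)c3)CC(O)C2=O)cc1N` was also tested, and in this assay compound 2 returns > 100 ug/mL, which is a limit of the assay rather than a number. So compound 1 stands as the one compound with a measured value, with the other value sitting at the limit of > 100 ug/mL in this assay, at which 1 of the 2 values shown sits.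

Compound 3 `COc1ccc(C2=C(c3cc(OC)c(OC)c(OC)c3)C(=O)C(OC(C)=O)C2)cc1OC(C)C` has not yet been measured in this assay. It differs from compound 1 in one place: isopropoxy in place of chloro on an aromatic carbon. Going by the values given here, no measured pair here shows what such a change does, so there is no step to lean on. The expected step from compound 1 to compound 3 in this assay is a 1.3-fold higher number from compound 1 to compound 3 (0.10 log units; within the scatter), which is not beyond the usual scatter. Compound 3 is therefore estimated at 75 ug/mL, with a range from 30 ug/mL to 150 ug/mL.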

Compound 3, half-maximal inhibitory concentration: > 100 ug/mL
Compound 3: no number, only a limit; the forecaster's own chance of this, stated with the estimate: 35%; at least 1.3-fold (0.12 log units) between middle value and limit.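

In this assay, for the compounds shown here, this is the first change at this place on the ring that can be read: isopropoxy in place of chloro on an aromatic carbon gives an at least 1.6-fold higher number from compound 1 to compound 3 (0.22 log units; that floor lies within the scatter). That step is only a floor, and the floor itself does not clear the usual scatter, so the data show no stronger inhibition with isopropoxy but do not establish a real weakening. Compound 3 carries a limit, not a number, and it joins the compounds at that limit: the limit of > 100 ug/mL in this assay, at which 2 of the 3 values shown sit.

On these data alone, how far compound 3 truly lies from compound 1 stays open. So does the reading at this place for a bromo group, an ethoxy group or a longer chain such as butoxy, any of which could show whether size matters here.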